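The source may report more compounds than this note shows. Statements on the series, on what has been measured and on what is new or still open speak of the compounds shown alone.

Compound 1 `CC(C)c1noc(N2CCC(Oc3cc(N4CCc5cc(C6CCCCC6=O)ccc54)ncn3)CC2)n1` gives 4.7 in a physicochemical assay for lipophilicity, measured as octanol-water partition, at pH 7.4 (a higher number here means a more lipophilic compound, a lower number a more polar compound), and stands highest of the two numbers measured; the nearest is compound 2 `CC(C)c1noc(N2CCC(Oc3cc(N4CCc5cc(S(=O)(=O)CCO)ccc54)ncn3)CC2)n1`, which gives 2.7. The step of a number 2.00 log units lower from compound 1 to compound 2 (beyond the scatter) is the only one measured, and it bears directly on compound 3 `CC(C)c1noc(N2CCC(Oc3cc(N4CCc5cc(S(C)(=O)=O)ccc54)ncn3)CC2)n1`, whose change from compound 1 is methylsulfonyl in place of 2-oxocyclohexyl on an aromatic carbon. The change in hand is of the same kind as that step, so a large drop, a little smaller, is expected: a number 1.70 log units lower from compound 1 to compound 3 (beyond the scatter). For compound 3 the expected value is 3, within 2.5 to 3.6.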

Compound 3, distribution coefficient: 3.1
Estimate against measurement, compound 3: 0.10 log units below; low and high end bracket the measured number.
By their numbers in this assay, from the lowest: compound 2; then compound 3; then compound 1.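

At this aromatic carbon in this assay, methylsulfonyl in place of 2-oxocyclohexyl also gives a large step (a number 1.60 log units lower from compound 1 to compound 3 (beyond the scatter)), so the large drop is not confined to the (2-hydroxyethyl)sulfonyl group. Within the sulfonyl pair, hydrogen in place of hydroxymethyl on the chain carbon bound to the sulfonyl sulfur gives a modest step (a number 0.40 log units higher from compound 2 to compound 3 (beyond the scatter)), so the chain end also counts, though less. Nothing available gives a cause for either step. Open remains how a longer chain on the sulfonyl sulfur, or an amine at its end, would compare. Also open, as far as these compounds go, is where a carboxylic acid at this aromatic carbon would fall.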